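Ester versus acid on a cinnamate-bearing pyrazine ester series

The source may hold more compounds than are shown below. What is called first, only, known or untested is meant among the compounds shown, and "the series" means these compounds.

Three compounds share a pyrazine ester attached to a phenyl ring carrying a cinnamic acid or ester chain. Compound 1 `COc1ccc(OC(=O)c2nc(C)c(C)nc2C)c(/C=C/C(=O)O)c1`, compound 2 `COc1ccc(/C=C/C(=O)O)cc1OC(=O)c1nc(C)c(C)nc1C` and compound 3 `CCOC(=O)/C=C/c1ccc(OC)c(OC(=O)c2nc(C)c(C)nc2C)c1` were tested in a functional assay on EA.hy 926 cells (Homo sapiens) for cytotoxicity, read by MTT assay, with stated times of 24 h and 12 h; a higher number here means that more compound is needed for the effect, a lower number that less compound is needed. Compound 2 gives 8800 nM, while compound 3 gives 29900 nM. The change from compound 2 to compound 3, (ethyl in place of hydrogen on an oxygen next to a carbonyl group), produced a 3.4-fold higher number from compound 2 to compound 3 (0.53 log units; beyond the scatter). Compound 1 gives 48600 nM. How the core of compound 1 differs from that of compound 2 is not broken down here, and the two values stand beyond the scatter of each other, whereas compound 1 and compound 3 lie within it. Compound 4 `CCOC(=O)/C=C/c1cc(OC)ccc1OC(=O)c1nc(C)c(C)nc1C` is not yet measured; it differs from compound 1 by ethyl in place of hydrogen on an oxygen next to a carbonyl group, the same change seen between compound 2 and compound 3, at an identically described place. From compound 1 to compound 4 a step of about a 3.1-fold higher number from compound 1 to compound 4 (0.49 log units; beyond the scatter) is expected, because the same change gave a 3.4-fold higher number from compound 2 to compound 3 (0.53 log units; beyond the scatter). Compound 4 is therefore estimated at 150000 nM, most likely between 50000 nM and 400000 nM.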

Compound 4, half-maximal effective concentration: 105000 nM
Beside the measured number, compound 4's estimate is 1.4-fold (0.15 log units) above it; low and high end bracket the measured number.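

In this assay, replacing the hydrogen of the carboxy group with ethyl, which gives ethoxycarbonyl, raises the number again, with a 2.2-fold higher number from compound 1 to compound 4 (0.33 log units; beyond the scatter). The two cores respond in the same direction, and the sizes of their steps do not differ beyond what repeated measurement allows: the same change on two cores in this assay, a 3.4-fold higher number (0.53 log units; beyond the scatter) from compound 2 to compound 3 and a 2.2-fold higher number (0.33 log units; beyond the scatter) from compound 1 to compound 4, 1.6-fold (0.20 log units) apart, within the scatter of two such steps. This shows that, on these two cores and in this one assay, the ethyl ester needs more compound for the effect than the matching acid, but it does not show why, and two cores are too few to predict the step on any other core in the series.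

The compounds shown carry only hydrogen or ethyl on this oxygen, so it remains open what a methyl group, a longer chain such as butyl, or an amide in place of the ester would do. Going by these compounds, it also remains open whether the same step would appear on any other cell type.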